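The source may report more compounds than this note shows. Statements on the series, on what has been measured and on what is new or still open speak of the compounds shown alone.

Measured so far:
compound 1 `NC(=O)c1c(NC(=O)c2ccccc2Cl)sc2c1CCNC2`: 45000 nM in a functional assay on HeLa cells (Homo sapiens) for antiproliferative activity, with a stated time of 24 h; a lower number here means a stronger inhibitor, a higher number a weaker inhibitor
compound 2 `NC(=O)c1c(NC(=O)c2ccccc2Cl)sc2c1CCN(Cc1ccc(Cl)cc1Cl)C2`: 21100 nM in this assay

Going by the values given here, compound 2 holds the lowest of the two numbers; the only known step is a 2.1-fold lower number from compound 1 to compound 2 (0.33 log units; beyond the scatter), a modest gain. Compound 3 `Cc1ccccc1NC(=S)N1CCc2c(sc(NC(=O)c3ccccc3Cl)c2C(N)=O)C1` differs from compound 2 by a group of 10 heavy atoms (8 carbon, 1 nitrogen, 1 sulfur; one six-membered aromatic ring of carbon only) in place of a group of 9 heavy atoms (7 carbon, 2 chlorine; one six-membered aromatic ring of carbon only), on an amine nitrogen in a ring. Among the compounds with values here, the step of a 2.1-fold lower number from compound 1 to compound 2 (0.33 log units; beyond the scatter) bears on the same ring nitrogen, but it sets a group in place of hydrogen; no step swaps one group for another there, so its size is no guide to this exchange. A step within the scatter, in either direction, is expected, a 1.0-fold higher number from compound 2 to compound 3 (0.02 log units; within the scatter). Compound 3 is estimated at 22000 nM, range 7000 nM to 70000 nM.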

Compound 3, half-maximal inhibitory concentration: > 50000 nM
Compound 3: no number, only a limit; the forecaster's own chance of this, stated with the estimate: 15%; middle value at least 2.2-fold (0.35 log units) away from the limit.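

Compound 3 gives only a limit, not a number: the limit of > 50000 nM in this assay, at which 1 of the 3 values shown sits. On the amine nitrogen in the ring, the group itself matters, not only the presence of a group: replacing 2,4-dichlorobenzyl gives an at least 2.3-fold higher number from compound 2 to compound 3 (0.37 log units; beyond the scatter). Against the free amine, the same group gives an at least 1.1-fold higher number from compound 1 to compound 3 (0.04 log units; that floor lies within the scatter), so the gain seen with 2,4-dichlorobenzyl does not extend to every group on this nitrogen. Still open, going by these compounds, is whether an unsubstituted benzyl or an acetyl group here would match compound 2, and so whether the chlorines contribute to its gain.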